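The source may report more compounds than this note shows. Statements on the series, on what has been measured and on what is new or still open speak of the compounds shown alone.

Compound 2, with the structure `C=C1C(=O)[C@]23C[C@@]1(O)CC[C@H]2c1ccc(OS(=O)(=O)c2ccc(C)cc2)c(C)c1[C@@H]3Cn1cc(-c2ccc(Br)cc2)nn1`, gives 1630 nM in a functional assay on A549 cells (Homo sapiens) for cytotoxicity, read by MTT assay, with a stated time of 4 days (on this read-out higher numbers stand for weaker inhibition and lower numbers for stronger inhibition), the lowest of the two numbers seen so far. Compound 1, with the structure `C=C1C(=O)[C@]23C[C@@]1(O)CC[C@H]2c1ccc(OS(=O)(=O)c2ccc(C)cc2)c(C)c1[C@@H]3Cn1cc(-c2ccccn2)nn1`, gives 2310 nM in this assay. Among the compounds with values here, the one measured step, a 1.4-fold lower number from compound 1 to compound 2 (0.15 log units; within the scatter), stays within the scatter. Compound 3, with the structure `C=C1C(=O)[C@]23C[C@@]1(O)CC[C@H]2c1ccc(OS(=O)(=O)c2ccc(C)cc2)c(C)c1[C@@H]3Cn1cc(-c2ccc(Cl)cc2)nn1`, differs from compound 2 by chloro in place of bromo on an aromatic carbon. Within the data shown here, no measured step covers this exact change. Among the measured compounds shown here, the only step available exchanged the whole aromatic group that hangs from the triazole, and even that left the number within the scatter, so exchanging one halogen for another there is expected to shift the number little, in no clear direction. Compound 3 is therefore expected to give about 1800 nM in this assay, with a range from 900 nM to 3600 nM. The expected step is a 1.1-fold higher number from compound 2 to compound 3 (0.04 log units; within the scatter), within the scatter.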

Compound 3, half-maximal inhibitory concentration: 1870 nM
Estimate against measurement, compound 3: 1.0-fold (0.02 log units) below; measured number inside the range.
By their numbers in this assay, from the lowest: compounds 2, 3 and 1 (each within the scatter of the next).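

In this assay, chloro in place of bromo gives a 1.1-fold higher number from compound 2 to compound 3 (0.06 log units; within the scatter), so the two halogens cannot be told apart at this place on the ring. The 4-chlorophenyl group also stays level with the pyridin-2-yl group, with a 1.2-fold lower number from compound 1 to compound 3 (0.09 log units; within the scatter), and so across these three compounds no exchange on the triazole moves the number beyond the scatter. Nothing measured here offers a reason for this flat result.

The compounds shown carry only a halogen on the phenyl ring or a pyridin-2-yl group in its place. On these data alone, it remains open whether an amine or a carboxylic acid on that ring, or a longer chain instead of the ring, would shift the number beyond the scatter.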